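Heteroaryl swap at the shared core: outlook for compound 4

The source may report more compounds than this note shows. Statements on the series, on what has been measured and on what is new or still open speak of the compounds shown alone.

Among the compounds with values here, compound 3 `Cc1cc(-c2noc([C@H](C)NC(=O)c3cc(C(F)(F)F)nn3C)n2)ncn1` gives 1410 nM in an assay on T-REx-293 cells for inhibition of potassium channel subfamily T member 1 (Homo sapiens), read by patch clamp (on this read-out lower numbers stand for stronger inhibition and higher numbers for weaker inhibition), the lowest of the two numbers measured so far; its nearest neighbour is compound 2 `Cc1ccnc(-c2noc([C@H](C)NC(=O)c3cc(C(F)(F)F)nn3C)n2)c1` with 4470 nM, a gap of a 3.2-fold lower number from compound 2 to compound 3 (0.50 log units; beyond the scatter). For compound 1 `Cc1cccc(-c2noc([C@H](C)NC(=O)c3cc(C(F)(F)F)nn3C)n2)n1` the read-out is a limit rather than a number, > 30000 nM, as recorded in the limit of > 30000 nM in this assay, at which 1 of the 3 values shown sits. The steps of an at least 6.7-fold lower number from compound 1 to compound 2 (0.82 log units; beyond the scatter) and an at least 21-fold lower number from compound 1 to compound 3 (1.32 log units; beyond the scatter) are therefore at least modest and large, but both start from that limit and their true size is open.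

Compound 4 `COCc1cc(-c2noc([C@H](C)NC(=O)c3cc(C(F)(F)F)nn3C)n2)ccn1` carries 2-(methoxymethyl)pyridin-4-yl in place of 6-methylpyrimidin-4-yl on an aromatic carbon. Within the data shown here, none of the measured steps touches a methoxymethyl group or a pyridin-4-yl ring; the closest precedent is a 3.2-fold lower number from compound 2 to compound 3 (0.50 log units; beyond the scatter), where the ring with two hetero atoms gave the lower number than the ring with one hetero atom. Given a 3.2-fold lower number from compound 2 to compound 3 (0.50 log units; beyond the scatter), compound 4, with its ring of one hetero atom, is expected to show a modest step toward a higher number in this assay, a 1.8-fold higher number from compound 3 to compound 4 (0.25 log units; within the scatter), near the edge of the scatter. Compound 4 is estimated at 2500 nM, with a range from 800 nM to 8000 nM.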

Compound 4, half-maximal inhibitory concentration: 322 nM
The estimate for compound 4 lay 7.8-fold (0.89 log units) above the measured number; the measured number lies below the stated range.
By their numbers in this assay, from the lowest: compound 4; then compound 3; then compound 2. At a limit, above all of these: compound 1.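

In this assay, exchanging 6-methylpyrimidin-4-yl for 2-(methoxymethyl)pyridin-4-yl on this aromatic carbon of the five-membered aromatic ring gives a 4.4-fold lower number from compound 3 to compound 4 (0.64 log units; beyond the scatter), and the change from 4-methylpyridin-2-yl gives a 14-fold lower number from compound 2 to compound 4 (1.14 log units; beyond the scatter). The count of ring hetero atoms therefore does not order the series: the rings with one hetero atom in compound 2 and compound 4 fall on either side of the ring with two hetero atoms in compound 3, and compound 1, also with one hetero atom, goes with compound 2 rather than compound 4. The widest span at this place is now an at least 93-fold lower number from compound 1 to compound 4 (1.96 log units; beyond the scatter), but compound 1 is recorded only as a limit and the true size of that step stays open: the limit of > 30000 nM in this assay, at which 1 of the 4 values shown sits.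

The step from compound 3 to compound 4 changes the ring and its substituent together, so the shares of the pyridin-4-yl ring and the methoxymethyl group cannot be separated from these compounds. Also open, from the compounds shown here alone, is how a hydroxymethyl group, a longer ether chain or an aminomethyl group on the same ring would read in this assay.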